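Replacing hydroxymethyl with trifluoromethyl: compound 3 to compound 4

The source may report more compounds than this note shows. Statements on the series, on what has been measured and on what is new or still open speak of the compounds shown alone.

The series shares the core of compound 1 `C#CCN(Cc1ccc2nc(C)nc(O)c2c1)c1ccccc1`. In a functional assay on L1210 cells (Mus musculus) for inhibition (on this read-out higher numbers stand for weaker inhibition and lower numbers for stronger inhibition), compound 1 is reported only as a limit, > 6500 nM. Compound 2 `C#CCN(Cc1ccc2nc(C)nc(O)c2c1)c1cccc(CC)c1`, carrying ethyl, gives 5000 nM. Compound 3 `C#CCN(Cc1ccc2nc(C)nc(O)c2c1)c1cccc(CO)c1`, carrying hydroxymethyl, gives 48000 nM, the higher of the two numbers, and so the weaker inhibition. Ethyl in place of hydrogen gives an at least 1.3-fold lower number from compound 1 to compound 2 (0.11 log units; that floor lies within the scatter). Hydroxymethyl in place of hydrogen gives a step that the limit leaves unreadable from compound 1 to compound 3. Both of these steps rest on (the limit of > 6500 nM in this assay, at which 1 of the 3 values shown sits).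

Compound 4 `C#CCN(Cc1ccc2nc(C)nc(O)c2c1)c1cccc(C(F)(F)F)c1` carries trifluoromethyl in place of hydroxymethyl on an aromatic carbon. The measured step that bears most directly on this change is a 9.6-fold higher number from compound 2 to compound 3 (0.98 log units; beyond the scatter), with hydroxy in place of methyl on a saturated chain carbon bound to an aromatic carbon. Hydroxymethyl leaves again in compound 4, so a step of similar size toward a lower number is expected in this assay. Trifluoromethyl itself has not been measured in this series, so the expectation carries a wide range. The estimated step is an 8.0-fold lower number from compound 3 to compound 4 (0.90 log units; beyond the scatter). The expected value for compound 4 is 6000 nM, with an estimated range of 2000 nM to 20000 nM.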

Compound 4, half-maximal inhibitory concentration: > 2200 nM
Compound 4: no number, only a limit; the forecaster's own chance of this, stated with the estimate: 25%; the middle value lies beyond the limit too.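

In this assay compound 4 is reported only as a limit (> 2200 nM). No step to compound 4 from compound 1, compound 2 or compound 3 can be read, as each rests on a limit: the limit of > 2200 nM in this assay, at which 1 of the 4 values shown sits.
On these data alone, whether trifluoromethyl in compound 4 stands nearer to ethyl in compound 2 or to hydroxymethyl in compound 3 in this assay remains open.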